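This account rests on a few compounds, and the source may have more. Where it says the series, first, only, none or still open, it means among the compounds named here.

In a toxicity assay on MDCK cells (Canis lupus familiaris) for cytotoxicity, read by crystal violet staining, with a stated time of 48 h (on this read-out lower numbers stand for higher toxicity in this test and higher numbers for lower toxicity in this test), three compounds built on the shared core have been tested, and each gave only a limit of the assay rather than a number. Compound 1 `Cc1ccc2cc(CN(Cc3ccc(F)cc3)Cc3ccc(C(C)(C)C)cc3)c(=O)[nH]c2c1` gives > 33000 nM, a limit. Compound 2 `CCc1ccc2[nH]c(=O)c(CN(Cc3ccc(C(C)(C)C)cc3)Cc3ccc(F)c(F)c3)cc2c1` gives > 33000 nM, also a limit. Compound 3 `CCOc1ccc(CN(Cc2ccc(C(C)(C)C)cc2)Cc2cc3cc(C)ccc3[nH]c2=O)cc1` gives > 10000 nM, again a limit. Compound 3 thus stands at the limit of > 10000 nM in this assay, at which 1 of the 3 values shown sits. The two other values sit at the limit of > 33000 nM in this assay, at which 2 of the 3 values shown sit. Compound 4 `Cc1ccc2[nH]c(=O)c(CN(Cc3ccc(SC(F)F)cc3)Cc3ccc(C(C)(C)C)cc3)cc2c1` differs from compound 3 in a single place: (difluoromethyl)sulfanyl in place of ethoxy on an aromatic carbon. No measured step between any two of these compounds exists. The change is expected to bring no shift beyond the usual scatter in this assay, so a step that the limit leaves unreadable from compound 3 to compound 4 is expected to be small. Compound 4 is estimated at 33000 nM, between 10000 nM and 100000 nM, and will most likely again be reported only as a limit.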

Compound 4, half-maximal cytotoxic concentration: > 5000 nM
Compound 4 gave a limit, no number (the forecaster's own chance of this, stated with the estimate: 85%); the middle value is on the limit's open side.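

Compound 3 and compound 4 each gave only a limit, so the step between them cannot be read. The compounds shown leave open what actual number, if any, each would reach in this assay.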